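The source may report more compounds than this note shows. Statements on the series, on what has been measured and on what is new or still open speak of the compounds shown alone.

Compound 2 `CN(Cc1cnc2nc(N)nc(N)c2n1)c1ccc(C(=O)NC(CCC(=O)NN)C(=O)O)cc1` gives 14.4 ug/mL in an assay for inhibition of Dihydrofolate reductase (Bos taurus) (on this read-out lower numbers stand for stronger inhibition and higher numbers for weaker inhibition), and its number lies within the scatter of the only other one shown, that of compound 1 `COC(=O)CCC(NC(=O)c1ccc(N(C)Cc2cnc3nc(N)nc(N)c3n2)cc1)C(=O)O`, which gives 11.9 ug/mL. Compound 3 `CN(Cc1cnc2nc(N)nc(N)c2n1)c1ccc(C(=O)NC(CCC(=O)NN)C(=O)NN)cc1` differs from compound 2 by aminoamino in place of hydroxy on a carbonyl carbon. Among the compounds with values here, the one step that bears on this is a 1.2-fold higher number from compound 1 to compound 2 (0.08 log units; within the scatter), a closely related exchange that left the number within the scatter. A step of similar size is therefore expected, a 1.0-fold lower number from compound 2 to compound 3 (0.01 log units; within the scatter), with no direction beyond the scatter. Compound 3 is estimated at 14 ug/mL, with a range from 7 ug/mL to 28 ug/mL.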

Compound 3, half-maximal inhibitory concentration: 18.3 ug/mL
For compound 3 the middle estimate is 1.3-fold (0.12 log units) below the measured one; the measured number falls inside the stated range.
By their numbers in this assay, from the lowest: compounds 1, 2 and 3 (each within the scatter of the next).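

In this assay, aminoamino in place of hydroxy on this carbonyl carbon stays within the scatter (a 1.3-fold higher number from compound 2 to compound 3 (0.10 log units; within the scatter)), so the carboxy group can give way to aminocarbamoyl with no readable change in the number. With 1,3-bis(aminocarbamoyl)propyl in place of 1-carboxy-3-(methoxycarbonyl)propyl, the step also stays within the scatter (a 1.5-fold higher number from compound 1 to compound 3 (0.19 log units; within the scatter)). No supporting data on why the number holds are available. Still open, going by these compounds, is whether a simple amine or a longer chain on this carbonyl carbon would move the number beyond the scatter.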